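The source may report more compounds than this note shows. Statements on the series, on what has been measured and on what is new or still open speak of the compounds shown alone.

Among the compounds with values here, compound 2 `Fc1ccc(-c2cn3ccnc3c(-c3ccc4ncn(C5CCCCC5)c4c3)n2)cc1` stands lowest of the two numbers measured so far in a functional assay on Hs-578T cells (Homo sapiens) for inhibition, read by sulforhodamine B assay, with a stated time of 48 h, tested at 10 uM (on this read-out lower numbers stand for less inhibition and higher numbers for more inhibition at the one concentration tested (going by the name of the read-out)), where compound 2 gives 17.6%. Within the data shown here, its nearest neighbour is compound 1 `O=Cc1ccc(-c2cn3ccnc3c(-c3ccc4ncn(C5CCCCC5)c4c3)n2)cc1`, which in this assay gives 45.5%; the one measured step, a number 27.9 percentage points lower from compound 1 to compound 2 (beyond the scatter), is beyond the scatter.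

Compound 3 `Brc1ccc(-c2cn3ccnc3c(-c3ccc4ncn(C5CCCCC5)c4c3)n2)cc1` differs from compound 2 in one place: bromo in place of fluoro on an aromatic carbon. Among the measured compounds shown here, no measured step exchanges one halogen for another, so the step from compound 1 to compound 2, with fluoro in place of formyl, bears on it only loosely: it shows that this position is sensitive to what sits on it, but not how bromo compares with fluoro. The expectation is therefore a step of modest size at most, a number 6.4 percentage points higher from compound 2 to compound 3 (within the scatter), with no clear direction beyond the scatter, and compound 3 is estimated at 24% in this assay, within a range from 8% to 42%.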

Compound 3, a percentage reported as inhibition, at one concentration (the size of the read-out at that concentration, not a potency): 24.5%
The estimate for compound 3 lay 0.5 percentage points below the measured number; low and high end bracket the measured number.
By their numbers in this assay, from the lowest: compounds 2 and 3 (each within the scatter of the next); then compound 1.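

In this assay, exchanging one halogen for the other on this aromatic carbon, para to a large group, gives a number 6.9 percentage points higher from compound 2 to compound 3 (within the scatter) and so does not separate bromo from fluoro. The formyl compound now stands apart from two halogen compounds rather than one, with a number 21 percentage points lower from compound 1 to compound 3 (beyond the scatter) showing that the gap first seen with fluoro also holds for bromo. Nothing available gives a reason for this gap.

From the compounds shown here alone, it remains open whether formyl is unusual at this position or whether other groups, such as an amine, a carboxylic acid or a methoxy group, would align with it or with the halogens. Also open, going by these compounds, is whether this grouping would hold for the same changes on the shared core at other concentrations or in other cell lines.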